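This account rests on a few compounds, and the source may have more. Where it says the series, first, only, none or still open, it means among the compounds named here.

Working notes on the series. For the measured compounds named here, in an in vitro ADME assay on microsomes from liver (Rattus norvegicus) for metabolic stability (on this read-out higher numbers stand for fast clearance and lower numbers for slow clearance), compound 1 (`CC(C)NC(=O)[C@H]1CC[C@@H](n2/c(=N/C(=O)c3ccccc3)[nH]c3ccc(CN4CCCCC4)cc32)CC1`) gives (389 mL.min-1.g-1) and compound 2 (`CCN(CC)C(=O)[C@H]1CC[C@@H](n2/c(=N/C(=O)c3ccccc3)[nH]c3ccc(CN4CCCCC4)cc32)CC1`) gives (682 mL.min-1.g-1), so compound 2 stands within the scatter of the only other measured compound. Compound 3 (`CCOC(=O)[C@H]1CC[C@@H](n2/c(=N/C(=O)c3ccccc3)[nH]c3ccc(CN4CCCCC4)cc32)CC1`) follows from compound 2 by one change (ethoxy in place of diethylamino on a carbonyl carbon): ethoxy in place of diethylamino on a carbonyl carbon. Going by the values given here, the one measured step at this carbonyl carbon is (a 1.8-fold higher number from compound 1 to compound 2 (0.24 log units; within the scatter)), diethylamino in place of isopropylamino, and it lies within the scatter. Among the compounds with values here, no measured compound carries ethoxy there, so the data leave the direction open and the range must stay wide. On that single step, no change beyond the scatter is expected in this assay. The estimated step is (a 1.2-fold lower number from compound 2 to compound 3 (0.09 log units; within the scatter)). The expected value for compound 3 is (550 mL.min-1.g-1), with an estimated range from (200 mL.min-1.g-1) to (1400 mL.min-1.g-1).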

Compound 3, intrinsic clearance in microsomes: 706 mL.min-1.g-1
Compound 3: middle estimate off by 1.3-fold (0.11 log units), on the low side, within the range that was stated.
By their numbers in this assay, from the lowest: compounds 1, 2 and 3 (each within the scatter of the next).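

In this assay, ethoxy in place of diethylamino on a carbonyl carbon gives a 1.0-fold higher number from compound 2 to compound 3 (0.02 log units; within the scatter), and ethoxy in place of isopropylamino gives a 1.8-fold higher number from compound 1 to compound 3 (0.26 log units; within the scatter). For the compounds shown here, the earlier compounds covered only two amino groups at this carbonyl carbon; with ethoxy, a group attached through oxygen also falls within the scatter of both, so exchanging nitrogen for oxygen at this point produces no readable change across compound 1, compound 2 and compound 3. Nothing available on these compounds bears on the reason for this flat reading.

As far as these compounds go, whether the flat reading extends to a carboxylic acid or a longer alkoxy chain on this carbonyl carbon stays open. From the compounds shown here alone, all three compounds also vary in this one place only, so whether the same exchange would read alike on a different core is unknown.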